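Replacing a Cyclopentyl Amine with a Spirocyclic Diamine

The source may report more compounds than this note shows. Statements on the series, on what has been measured and on what is new or still open speak of the compounds shown alone.

In a functional assay on HEK293 cells for activation of melanin-concentrating hormone receptor 1 (Rattus norvegicus), read by inositol phosphate accumulation (a lower number here means that less compound is needed, a higher number that more compound is needed for the effect), compound 2 `CN(c1ccc2cc(NC(=O)CCc3ccc(C(F)(F)F)cc3)ccc2n1)C1CCCC1` gives 350 nM, the lower of the two single numbers, the other being compound 1 `CN(c1ccc2cc(NC(=O)CCc3ccc(C(F)(F)F)cc3)ccc2n1)C1CCCCC1` with 1200 nM. Compound 3 `O=C(CCc1ccc(C(F)(F)F)cc1)Nc1ccc2nc(N3CCCC3)ccc2c1` gives 320 nM; 320 nM (2 entries), close to compound 2. The step of a 3.4-fold lower number from compound 1 to compound 2 (0.54 log units; beyond the scatter) shows that ring size on that nitrogen mattered modestly. Compound 4 `O=C(CCc1ccc(C(F)(F)F)cc1)Nc1ccc2nc(N3CCC4(CCNC4)C3)ccc2c1` carries a group of 9 heavy atoms (7 carbon, 2 nitrogen; 2 five-membered non-aromatic rings with 1 hetero atom each) in place of a group of 7 heavy atoms (6 carbon, 1 nitrogen; one five-membered non-aromatic ring of carbon only), on an aromatic carbon. Among the compounds with values here, no measured step removes the methyl or adds a second ring, so only a 3.4-fold lower number from compound 1 to compound 2 (0.54 log units; beyond the scatter) bears on it, and compound 2 and compound 3 together show that a five-membered ring with a nitrogen on the shared core gives a similar number. A change within or only just beyond the scatter is therefore expected. Compound 4 is estimated at 500 nM (range 150 nM to 2000 nM), an expected step of a 1.4-fold higher number from compound 2 to compound 4 (0.15 log units; within the scatter).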

Compound 4, half-maximal effective concentration: 140 nM
Beside the measured number, compound 4's estimate is 3.6-fold (0.55 log units) above it; measured number below the stated range.
By their numbers in this assay, from the lowest: compound 4; then compound 2; then compound 1.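

In this assay, this position, on an aromatic carbon next to the ring nitrogen, accepts a larger group with two rings and a hydrogen-bond donor, giving a 2.5-fold lower number from compound 2 to compound 4 (0.40 log units; beyond the scatter). The larger group also gives an 8.6-fold lower number from compound 1 to compound 4 (0.93 log units; beyond the scatter), so a bigger group here does not always bring a higher number, as cyclohexyl had suggested. Nothing available explains this change. Whether the second ring or its nitrogen hydrogen accounts for the step stays open; a methyl on that nitrogen, or an open aminoethyl chain in place of the second ring, would separate the two.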